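This account rests on a few compounds, and the source may have more. Where it says the series, first, only, none or still open, it means among the compounds named here.

Measured compounds:
compound 1, `Cc1cnc2[nH]c(-c3cccc(F)c3)cc(=O)c2c1`: 537 nM
compound 2, `Cc1ccc2c(O)cc(-c3cccc(Cl)c3)nc2n1`: 3800 nM

Both were tested in a functional assay on cells (Panel breast (Carcinoma cell lines), Homo sapiens) for inhibition; on this read-out lower numbers stand for stronger inhibition of growth and higher numbers for weaker inhibition of growth. Compound 2 has the higher of the two numbers, and its gap to compound 1 lies beyond the usual scatter of this assay. Compound 3, `Cc1cc(C)c2c(O)cc(-c3cccc(Cl)c3)nc2n1`, differs from compound 2 in one place: methyl in place of hydrogen on an aromatic carbon. Within the data shown here, no measured pair shows what this change does here, so only a small step is expected, a 1.3-fold lower number from compound 2 to compound 3 (0.10 log units; within the scatter), in either direction or none beyond the scatter. Compound 3 is therefore estimated at 3000 nM in this assay, with a range from 800 nM to 12000 nM.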

Compound 3, concentration for total growth inhibition: 1230 nM
Compound 3: the middle estimate sits 2.4-fold (0.39 log units) above what was measured; the measured number falls inside the stated range.
By their numbers in this assay, from the lowest: compound 1; then compound 3; then compound 2.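

In this assay, placing a methyl on this aromatic carbon, opposite the ring nitrogen, gives a 3.1-fold lower number from compound 2 to compound 3 (0.49 log units; beyond the scatter). This is a modest step, but it lies beyond the scatter, so this position accepts a methyl group and growth inhibition becomes stronger rather than weaker. Nothing available explains why the number falls.

Going by these compounds, whether a longer chain such as ethyl would strengthen inhibition further at this carbon remains open. So does the outcome with a different kind of group there, such as an amine or a carboxylic acid.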